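Notes on a heteroaryl swap at the six-membered ring

The source may hold more compounds than are shown below. What is called first, only, known or untested is meant among the compounds shown, and "the series" means these compounds.

Compound 2 `Cc1cc(N2CCCC2)cn2c(CSCCc3ccccc3)cnc12` is one of three measured members of the series. In an ADME assay on HEL cells (Homo sapiens) for cytotoxicity, with a stated time of 3 days (a lower number here means that less compound is tolerated, a higher number that more compound is tolerated), compound 2 gives 20 ug/mL, level at the digits shown with compound 3 `Cc1cc(-n2cccc2)cn2c(CSCc3ccccc3)cnc12`, for which 20 ug/mL is found, and the two together are the highest of the three numbers. Compound 1 `Cc1cc(-c2ccsc2)cn2c(CSCc3ccccc3)cnc12` gives 4 ug/mL, which is the lower number of the set. Among the compounds with values here, the only single-point step measured so far is a 5.0-fold higher number from compound 1 to compound 3 (0.70 log units; beyond the scatter), which shows that an exchange of the aromatic group on the six-membered ring can move this assay by a modest amount beyond the scatter.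

Compound 4 `Cc1cc(-n2ccc3cccnc32)cn2c(CSCCc3ccccc3)cnc12` is not yet measured. Compared with compound 2 it carries a group of 9 heavy atoms (7 carbon, 2 nitrogen; one five-membered aromatic ring with 1 hetero atom, one six-membered aromatic ring with 1 hetero atom) in place of a group of 5 heavy atoms (4 carbon, 1 nitrogen; one five-membered non-aromatic ring with 1 hetero atom), on an aromatic carbon. Within the data shown here, no measured step replaces pyrrolidin-1-yl with an aromatic group, so the step from compound 1 to compound 3 is the nearest guide in size, not in direction. For compound 4 the expected result in this assay is therefore 10 ug/mL, estimated to lie between 4 ug/mL and 25 ug/mL. Among the measured compounds shown here, this expectation corresponds to an estimated step of a 2.0-fold lower number from compound 2 to compound 4 (0.30 log units; within the scatter), a change on the order of the one seen between compound 1 and compound 3, with the direction uncertain.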

Compound 4, minimum cytotoxic concentration: 20 ug/mL
Compound 4: middle estimate off by 2.0-fold (0.30 log units), on the low side; low and high end bracket the measured number.
By their numbers in this assay, from the lowest: compound 1; then compounds 2, 3 and 4 (each within the scatter of the next).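

In this assay, within the data shown here, the exchange of pyrrolidin-1-yl for the fused aromatic group of 9 heavy atoms, on the aromatic carbon two atoms from the ring nitrogen, gives no change at the digits printed from compound 2 to compound 4 (within the scatter) and so adds a first case where a change at this position leaves the number in place. Set against a 5.0-fold higher number from compound 1 to compound 3 (0.70 log units; beyond the scatter) on the other side chain, this shows that an exchange here does not always move the number, and that in this pair a non-aromatic ring of 5 heavy atoms and a two-ring aromatic group of 9 heavy atoms read alike. Nothing is available that would explain why the number holds level in this pair.

As far as these compounds go, it remains open whether thiophen-3-yl or 1H-pyrrol-1-yl would give the same separation on the side chain shared by compound 2 and compound 4, since each of the two steps rests on a single pair. Also open, from the compounds shown here alone, is how an open-chain amine such as dimethylamino, a carboxylic acid, or a longer chain between sulfur and phenyl would read in this assay at these two places.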